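Swapping propyl for cyano on the amide phenyl ring

The compounds below may be only part of what the source reports. "The series", "measured", "known", "first", "only" and "open" are said of these compounds alone.

Compound 1 `CC(=O)Nc1cccc(NC(=O)COc2ccc3c(=O)ccoc3c2)c1` in an assay on isolated protein for inhibition of Rho-associated protein kinase 1 (Homo sapiens), read by scintillation counting, radiometric assay and 33P incorporation, with a stated time of 40 min, in the presence of a further agent that is not named here (on this read-out higher numbers stand for weaker inhibition and lower numbers for stronger inhibition), gives 2500 nM.
Compound 2 `Cc1ccc(C(=O)Nc2cccc(NC(=O)COc3ccc4c(=O)ccoc4c3)c2)cc1` in this assay gives 183 nM.
Compound 3 `CCCc1ccc(C(=O)Nc2cccc(NC(=O)COc3ccc4c(=O)ccoc4c3)c2)cc1` in this assay gives 143 nM.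

All three share one core and differ only in the group attached to the carbonyl carbon of one amide. Compound 3 shows the lowest number of the three, but its gap to compound 2 lies within the scatter, so those two cannot be ranked; only compound 1 stands clearly apart. The next step leads to compound 4 `N#Cc1ccc(C(=O)Nc2cccc(NC(=O)COc3ccc4c(=O)ccoc4c3)c2)cc1`, and the change is cyano in place of propyl on an aromatic carbon. Among the measured compounds shown here, three measured steps bear on this. a 14-fold lower number from compound 1 to compound 2 (1.14 log units; beyond the scatter) and a 17-fold lower number from compound 1 to compound 3 (1.24 log units; beyond the scatter) show that putting a 4-methylphenyl or 4-propylphenyl in place of methyl on the carbonyl carbon brought a large gain, while a 1.3-fold lower number from compound 2 to compound 3 (0.11 log units; within the scatter) shows that ethyl in place of hydrogen on the saturated chain carbon bound to the aromatic carbon changed little. Compound 4 keeps the phenyl ring and alters only the group para to the large group. For the measured compounds named here, no measured step exchanges an alkyl chain for cyano, so the expectation for compound 4 is a number close to that of compound 3, with a wide range allowing for a modest weakening. Compound 4 is therefore expected to give 250 nM in this assay, with a range from 80 nM to 800 nM. For compound 4 the expected step is a 1.7-fold higher number from compound 3 to compound 4 (0.24 log units; within the scatter).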

Compound 4, half-maximal inhibitory concentration: 123 nM
Compound 4: the middle estimate sits 2.0-fold (0.31 log units) above what was measured; the measured number falls inside the stated range.
By their numbers in this assay, from the lowest: compounds 4, 3 and 2 (each within the scatter of the next); then compound 1.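

In this assay, a cyano group, which brings a triple bond and a hydrogen-bond acceptor, takes the place of an alkyl group on this aromatic carbon with no change beyond the scatter (a 1.2-fold lower number from compound 3 to compound 4 (0.07 log units; within the scatter)) (a 1.5-fold lower number from compound 2 to compound 4 (0.17 log units; within the scatter)), so among these compounds the position para to a large group holds propyl, methyl or cyano with readings that cannot be ranked. The large gain over the simple methyl on the carbonyl carbon therefore also appears with the 4-cyanophenyl group (a 20-fold lower number from compound 1 to compound 4 (1.31 log units; beyond the scatter)), and it is seen in compound 2, compound 3 and compound 4 alike. No measurement here explains why these groups read alike.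

Still open, going by these compounds, is how a plain phenyl, with only hydrogen at this position, would compare. Also open, on these data alone, is whether a carboxylic acid, an amine or a longer chain such as hexyl would fit here as well.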